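This account rests on a few compounds, and the source may have more. Where it says the series, first, only, none or still open, it means among the compounds named here.

Measured compounds:
Compound 1 `COc1ccc(/C=N/NC(=O)c2cc(OC)c(OC)c(OC)c2)c(OC)c1` gives 3.6% in a functional assay on BGC-823 cells (Homo sapiens) for antiproliferative activity, read by MTT assay, tested at 5 uM; a lower number here means a weaker effect, a higher number a stronger effect of the compound at the concentration tested.
Compound 2 `COc1cc(C2=NN(C(C)=O)C(c3cc(Cl)cc(Cl)c3)O2)cc(OC)c1OC` gives 6.6% in this assay.
Compound 3 `COc1ccc(OC)c(/C=N/NC(=O)c2cc(OC)c(OC)c(OC)c2)c1` gives 10.1% in this assay.

All three numbers are small, and the gaps among them fall within the usual scatter of repeated measurements. Compound 2 lies within the scatter of compound 1, its nearest neighbour, and also within the scatter of compound 3, the furthest of the three; no ordering among them can be read from these numbers. Going by the values given here, compound 1 and compound 3 share a core that differs from the core of compound 2, and no pair of measured compounds differs in only one place, so no measured step shows how a single change shifts the read-out.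

Compound 4 `COc1cc(C2=NN(C(C)=O)C(c3cccc(C(F)(F)F)c3)O2)cc(OC)c1OC` differs from compound 2 in one place: 3-(trifluoromethyl)phenyl in place of 3,5-dichlorophenyl on a saturated ring carbon. Among the compounds with values here, no measured step of this kind exists, so the expectation rests only on the small number of compound 2 6.6% and on the small numbers of the whole set. In this assay no step beyond the scatter is expected in either direction. The step of a number 0.4 percentage points higher from compound 2 to compound 4 (within the scatter) is expected to stay within the scatter. Compound 4 is estimated at 7%, within a range from 0% to 20%.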

Compound 4, a percentage reported as inhibition, at one concentration (the size of the read-out at that concentration, not a potency): 41.1%
Compound 4: the middle estimate sits 34.1 percentage points below what was measured, outside the stated range (above it).
By their numbers in this assay, from the lowest: compounds 1, 2 and 3 (each within the scatter of the next); then compound 4.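

In this assay, going by these compounds alone, the group on the saturated ring carbon is the first place where a single change moves the read-out beyond the scatter, with a number 34.5 percentage points higher from compound 2 to compound 4 (beyond the scatter) when 3-(trifluoromethyl)phenyl stands in place of 3,5-dichlorophenyl. The low number of compound 2 is therefore no fixed feature of the core it shares with compound 4, and the read-out on this core depends on which substituted phenyl sits at this position. The change removes both chlorine atoms and adds the trifluoromethyl group in one step, so this pair cannot apportion the step between what leaves and what enters, and nothing available here accounts for the size of the step.

As far as these compounds go, whether the trifluoromethyl group itself carries the read-out remains open, since a plain phenyl, or a phenyl bearing a nitrile, an amine or a carboxylic acid, would be needed to separate its contribution from the loss of the chlorine atoms. Also open, from the compounds shown here alone, is whether a longer chain in place of the acetyl group keeps the read-out of compound 4, a read-out that gives the size of the effect at one concentration only.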